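Dropping One Methoxy Group from Compound 1

The source may hold more compounds than are shown below. What is called first, only, known or untested is meant among the compounds shown, and "the series" means these compounds.

Going by the values given here, in a functional assay on DU-145 cells (Homo sapiens) for antiproliferative activity, read by MTT assay, with a stated time of 24 h (a higher number here means a weaker inhibitor, a lower number a stronger inhibitor), compound 1 `COc1cc(-c2cc(/C=C/C(=O)c3ccc(C)c(C)c3)nc3cc(-c4ccccc4)nn23)cc(OC)c1OC` gives 15400 nM, the lowest of the three numbers measured so far. Compound 2 `COc1cc(-c2cc(C(=O)/C=C/c3ccc(C)cc3)nc3cc(-c4ccccc4)nn23)cc(OC)c1OC` gives 21900 nM, and compound 3 `COc1cc(C(=O)/C=C/c2cc(-c3cc(OC)c(OC)c(OC)c3)n3nc(-c4ccccc4)cc3n2)cc(OC)c1OC` gives 34900 nM. The step of a 1.4-fold higher number from compound 1 to compound 2 (0.15 log units; within the scatter) stays within the scatter, while a 2.3-fold higher number from compound 1 to compound 3 (0.36 log units; beyond the scatter) is a modest step beyond it. Compound 4 `COc1ccc(-c2cc(/C=C/C(=O)c3ccc(C)c(C)c3)nc3cc(-c4ccccc4)nn23)cc1OC` differs from compound 1 only by hydrogen in place of methoxy on an aromatic carbon. Neither measured step alters the trimethoxyphenyl attached to the shared core: one rearranges the chain carrying the methylated phenyl ring, the other puts 3,4,5-trimethoxyphenyl in place of 3,4-dimethylphenyl on a carbonyl carbon. Among the compounds with values here, with no direct precedent and both earlier steps small, a change no larger than the scatter is expected, so a 1.2-fold higher number from compound 1 to compound 4 (0.07 log units; within the scatter) is the estimate. Compound 4 is therefore expected to give 18000 nM, between 9000 nM and 36000 nM.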

Compound 4, half-maximal inhibitory concentration: 12100 nM
Compound 4: middle estimate off by 1.5-fold (0.17 log units), on the high side, within the range that was stated.
By their numbers in this assay, from the lowest: compounds 4, 1, 2 and 3 (each within the scatter of the next, the first and the last beyond it).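

Putting hydrogen in place of one methoxy group, which turns 3,4,5-trimethoxyphenyl into 3,4-dimethoxyphenyl, gives a 1.3-fold lower number from compound 1 to compound 4 (0.10 log units; within the scatter) in this assay. This is the first step shown that touches this ring on the shared core, and the methoxy group at this place can go without a difference beyond the scatter. No measurement at hand explains this result. Still open, as far as these compounds go, is whether an amine or a longer chain such as butoxy at this place would leave the number as little moved, and whether the same holds once a second methoxy group is gone.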